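Swapping Bromo for Methoxy on a Shared Core

The source may hold more compounds than are shown below. What is called first, only, known or untested is meant among the compounds shown, and "the series" means these compounds.

Measured so far in a functional assay, tested at 400 ug/mL; a higher number here means a stronger effect of the compound at the concentration tested, a lower number a weaker effect: compound 1 `N#CC1=C(N)OC(c2c[nH]c3ccccc23)=C(C#N)C1c1ccccc1` gives 26.7%; compound 2 `CN(C)c1ccc(C2C(C#N)=C(N)OC(c3c[nH]c4ccccc34)=C2C#N)cc1` gives 26.7%; compound 3 `N#CC1=C(N)OC(c2c[nH]c3ccccc23)=C(C#N)C1c1ccc(Br)cc1` gives 22.7%.

Compound 3 sits within the scatter of the other two, as a number 4 percentage points lower from compound 1 to compound 3 (within the scatter) and a number 4 percentage points lower from compound 2 to compound 3 (within the scatter) show. Compound 4 `COc1ccc(C2C(C#N)=C(N)OC(c3c[nH]c4ccccc34)=C2C#N)cc1` differs from compound 3 in one place: methoxy in place of bromo on an aromatic carbon. Every measured step also changes the group on this same aromatic carbon, and none moved this assay beyond the scatter: no change at the digits printed from compound 1 to compound 2 (within the scatter), a number 4 percentage points lower from compound 1 to compound 3 (within the scatter), a number 4 percentage points lower from compound 2 to compound 3 (within the scatter). The step to compound 4 is therefore expected to be a number 2.3 percentage points higher from compound 3 to compound 4 (within the scatter), with no shift beyond the scatter in either direction. Compound 4 is estimated at 25%, in a range from 15% to 35%.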

Compound 4, a percentage reported as activity, at one concentration (the size of the read-out at that concentration, not a potency): 28.7%
Compound 4: the middle estimate sits 3.7 percentage points below what was measured, and the stated range covers the measured number.
By their numbers in this assay, from the lowest: compounds 3, 1, 2 and 4 (each within the scatter of the next).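

Methoxy joins hydrogen, dimethylamino and bromo at this aromatic carbon, and in this assay it stays within the scatter of each: against bromo (a number 6 percentage points higher from compound 3 to compound 4 (within the scatter)), against dimethylamino (a number 2 percentage points higher from compound 2 to compound 4 (within the scatter)) and against hydrogen (a number 2 percentage points higher from compound 1 to compound 4 (within the scatter)). Even the step from bromo, the largest at this position so far, does not separate the compounds. No evidence on hand gives a reason for this flat result.

As far as these compounds go, whether a carboxylic acid or a longer alkyl chain on this carbon would move the number beyond the scatter stays open. So does the effect of any change to the shared core.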